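Swapping Fluoro for Nitro on a Methoxyphenyl Ketone

This account rests on a few compounds, and the source may have more. Where it says the series, first, only, none or still open, it means among the compounds named here.

Measured so far:
compound 1 `COc1cc(C(=O)/C=C\Nc2ccc(-c3nc4cc(OC)c(OC)c(OC)c4s3)cc2C)cc(OC)c1OC` — 23300 nM
compound 2 `COc1ccc2nc(-c3ccc(N/C=C\C(=O)c4ccc(OC)c(F)c4)cc3)sc2c1` — 900 nM

Both compounds were tested in a functional assay on A549 cells (Homo sapiens) for antiproliferative activity, read by sulforhodamine B assay, with a stated time of 48 h; on this read-out lower numbers stand for stronger inhibition and higher numbers for weaker inhibition. Among the measured compounds shown here, compound 2 holds the lowest of the two numbers; its only neighbour is compound 1, whose number is higher by a gap that lies beyond the usual scatter of this kind of measurement. Compound 3 `COc1ccc2nc(-c3ccc(N/C=C\C(=O)c4ccc(OC)c([N+](=O)[O-])c4)cc3)sc2c1` has not yet been measured. It differs from compound 2 in a single place: nitro in place of fluoro on an aromatic carbon. The fluoro that leaves sits on an aromatic carbon of a six-membered aromatic ring of carbon only, ortho to a methoxy group and meta to a large group, and the nitro that enters takes that same place.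

For the measured compounds named here, no measured pair in this set shows what such an exchange does, so the expectation rests on compound 2 alone. The expected step is a small one, from compound 2 to compound 3 a 1.4-fold higher number from compound 2 to compound 3 (0.16 log units; within the scatter), leaning slightly toward a higher number but hardly beyond the scatter. Compound 3 is therefore expected to give about 1300 nM in this assay, with a likely range from 350 nM to 5000 nM.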

Compound 3, half-maximal inhibitory concentration: 13600 nM
Beside the measured number, compound 3's estimate is 10-fold (1.02 log units) below it; the whole stated range lies below it.
By their numbers in this assay, from the lowest: compound 2; then compounds 3 and 1 (each within the scatter of the next).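

Among the compounds shown here, this is the first exchange in the set that can be read at a single place, and it shows that this place is far from indifferent to what sits on it: in this assay, nitro in place of fluoro gives a 15-fold higher number from compound 2 to compound 3 (1.18 log units; beyond the scatter), a large loss of inhibition. On the aromatic carbon ortho to a methoxy group, fluoro therefore serves much better than nitro in this one pair, and a single exchange on this ring is enough to move the number well past ordinary repeat variation. What lies behind the step cannot be told, as no measurement of any property of these compounds is at hand.

With only fluoro and nitro seen on this carbon, the compounds shown leave open how a plain hydrogen, a chlorine atom, a nitrile or an amine would fare there, and whether any of them would give a lower number than compound 2 does. Also open, on these data alone, is whether nitro in place of fluoro would cost as much if the methoxy group on the same ring were replaced by a hydroxyl group or a longer ether chain.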